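Phenoxyacetamide series: a rearranged methoxy group

A few compounds are considered here, and "the series" means these few. Any claim that something is new, unique, unknown or untested is made for them only; others in the source may bear on it.

Compound 1 `O=C(COc1ccc2ccccc2c1)N1CCN(C(c2ccc(Br)cc2)c2ccc(Br)cc2)CC1` and compound 2 `COc1ccc(OCC(=O)N2CCN(C(c3ccc(Br)cc3)c3ccc(Br)cc3)CC2)cc1` share one core. In a functional assay on PC-12 cells (Rattus norvegicus) for cytotoxicity, read by MTT assay, with a stated time of 24 h, tested at 0.1 uM (a lower number here means a weaker effect, a higher number a stronger effect of the compound at the concentration tested), compound 1 gives 4.06%, and compound 2 gives 3.52%. Compound 2 holds the lower of the two numbers, yet the step of a number 0.5 percentage points lower from compound 1 to compound 2 (within the scatter) lies within the scatter, so the two are not told apart. Compound 3 `COc1ccccc1OCC(=O)N1CCN(C(c2ccc(Br)cc2)c2ccc(Br)cc2)CC1` differs from compound 2 by 2-methoxyphenyl in place of 4-methoxyphenyl on an oxygen on a saturated carbon. For the measured compounds named here, no measured step covers this exact difference; the only step, a number 0.5 percentage points lower from compound 1 to compound 2 (within the scatter), exchanged the group on an oxygen on a saturated carbon without effect beyond the scatter. For compound 3 no step beyond the scatter is therefore expected, namely a number 0.5 percentage points higher from compound 2 to compound 3 (within the scatter). Compound 3 is estimated at 4%, between 0% and 13%.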

Compound 3, a percentage reported as activity, at one concentration (the size of the read-out at that concentration, not a potency): 45.5%
For compound 3 the middle estimate is 41.5 percentage points below the measured one, outside the stated range (above it).
By their numbers in this assay, from the lowest: compounds 2 and 1 (each within the scatter of the next); then compound 3.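

In this assay, the group on an oxygen on a saturated carbon is not interchangeable: 2-methoxyphenyl in place of 4-methoxyphenyl, with the same atoms joined differently, gives a number 42 percentage points higher from compound 2 to compound 3 (beyond the scatter) in this series. 2-Methoxyphenyl in place of naphthalen-2-yl gives a number 41.4 percentage points higher from compound 1 to compound 3 (beyond the scatter) as well, so compound 3 stands apart from both earlier compounds. On these data alone, whether this holds with an ethoxy group or an amine in place of the methoxy group of 2-methoxyphenyl stays open. No evidence at hand bears on the difference between the two methoxyphenyl groups.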